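From thiophen-2-yl to 2,6-dichlorophenyl on a shared core

The source may report more compounds than this note shows. Statements on the series, on what has been measured and on what is new or still open speak of the compounds shown alone.

In a functional assay on Jurkat cells (Homo sapiens) for cytotoxicity, read by MTT assay, with a stated time of 24 h (a lower number here means that less compound is needed, a higher number that more compound is needed for the effect), compound 1 (`CCOC(=O)c1cc([Se]c2ccccc2)c2cc(OC)ccc2n1`) gives 102000 nM, and compound 2 (`COc1ccc2nc(-c3cccs3)cc([Se]c3ccccc3)c2c1`) gives 99800 nM. Within the data shown here, compound 2 therefore stands level with compound 1, the only other number available. Compound 3 (`COc1ccc2nc(-c3c(Cl)cccc3Cl)cc([Se]c3ccccc3)c2c1`) keeps the shared core but carries 2,6-dichlorophenyl in place of thiophen-2-yl on an aromatic carbon next to the ring nitrogen: 2,6-dichlorophenyl in place of thiophen-2-yl on an aromatic carbon. Among the measured compounds shown here, only one measured step bears on this change. Replacing ethoxycarbonyl with thiophen-2-yl at the same place gave a 1.0-fold lower number from compound 1 to compound 2 (0.01 log units; within the scatter). For the measured compounds named here, a single step is thin evidence, and no measured compound yet carries 2,6-dichlorophenyl. Even so, no shift beyond the scatter is expected in this assay, in either direction. The expected step is a 1.1-fold lower number from compound 2 to compound 3 (0.04 log units; within the scatter). For compound 3 the estimated value is 90000 nM, with an expected range from 40000 nM to 190000 nM.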

Compound 3, half-maximal effective concentration: 17000 nM
Compound 3: middle estimate off by 5.3-fold (0.72 log units), on the high side; the measured number lies below the stated range.
By their numbers in this assay, from the lowest: compound 3; then compounds 2 and 1 (each within the scatter of the next).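

At this place, on an aromatic carbon next to the ring nitrogen, the group can change the result in this assay: the step to 2,6-dichlorophenyl gives a 5.9-fold lower number from compound 2 to compound 3 (0.77 log units; beyond the scatter), whereas ethoxycarbonyl and thiophen-2-yl had stayed level with each other. The step of a 6.0-fold lower number from compound 1 to compound 3 (0.78 log units; beyond the scatter) likewise lies beyond the scatter, so 2,6-dichlorophenyl stands apart from both earlier groups, and the position is not indifferent to what it carries. No measurement shown here accounts for this difference.

The compounds shown leave open whether the lower number goes with the two chlorines or with the six-membered carbon ring itself. A plain phenyl or a phenyl with a single chlorine would separate those two readings, and an amine or a carboxylic acid at this place would test a different kind of group.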